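The source may hold more compounds than are shown below. What is called first, only, known or untested is meant among the compounds shown, and "the series" means these compounds.

Compound 1 `COc1cc(/C=C/C(=O)c2cccc(-n3cc(-c4ccccc4)[nH]c3=O)c2)ccc1O` belongs to a small group of three compounds that share one core and differ in the substituents on the cinnamoyl side. In a functional assay on NCI-H522 cells (Homo sapiens) for inhibition (on this read-out higher numbers stand for weaker inhibition of growth and lower numbers for stronger inhibition of growth), compound 1 gives 2360 nM, which is the higher of the two numbers obtained. Compound 3 `COc1cc(/C=C/C(=O)c2cccc(-n3cc(-c4ccccc4)[nH]c3=O)c2)cc(OC)c1OC` carries three methoxy groups on that side, and in this assay compound 3 gives 950 nM, a lower number than compound 1 by a gap that is beyond the usual scatter. Compound 2 `O=C(/C=C/c1cccc(O)c1)c1cccc(-n2cc(-c3ccccc3)[nH]c2=O)c1` is part of the same group, but in this assay compound 2 gives "not determined" (no result reported), so no number is known for it.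

Compound 4 `COc1ccc(-c2cn(-c3cccc(C(=O)/C=C/c4ccc(O)c(OC)c4)c3)c(=O)[nH]2)cc1` departs from compound 1 at the other end of the molecule: methoxy in place of hydrogen on an aromatic carbon. Among the measured compounds shown here, no pair of measured compounds shows this particular change, so its size can only be guessed. Since the change touches a different ring than the one varied in compound 3, and since the shown values move only modestly, the step is expected to be small, perhaps a slight lowering and possibly no more than the scatter. Compound 4 is therefore estimated at 1800 nM, with a range from 700 nM to 4500 nM, which means an expected step of a 1.3-fold lower number from compound 1 to compound 4 (0.12 log units; within the scatter).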

Compound 4, concentration for 50% growth inhibition: 3480 nM
For compound 4 the middle estimate is 1.9-fold (0.29 log units) below the measured one; low and high end bracket the measured number.
By their numbers in this assay, from the lowest: compound 3; then compounds 1 and 4 (each within the scatter of the next).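

Earlier compounds varied only the cinnamoyl side, so compound 4 gives the first reading from the other end of the molecule. In this assay the change from phenyl to 4-methoxyphenyl, para to a large group, gives a step that stays within the usual scatter (a 1.5-fold higher number from compound 1 to compound 4 (0.17 log units; within the scatter)), so compound 1 and compound 4 cannot be told apart in this test, and this position accepts methoxy in place of hydrogen without a clear shift in the read-out. No separate measurement is available to explain this result.

Still open, from the compounds shown here alone, is whether this position would respond differently to an amine, a carboxylic acid or a longer chain in place of methoxy. It is also unknown whether methoxy at this place would read the same on the core of compound 3, which carries three methoxy groups on the cinnamoyl side.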